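Thiazolyl on the Amino Group of Compound 3

The compounds below may be only part of what the source reports. "The series", "measured", "known", "first", "only" and "open" are said of these compounds alone.

Three compounds share a core carrying the same cyclopentane-diol side chain. In an ADME assay on cells (Homo sapiens) for cytotoxicity, read by polymerase chain reaction, with a stated time of 3 days (a lower number here means that less compound is tolerated, a higher number that more compound is tolerated), compound 1 `Nc1nc(Cl)c(-c2nc3ccc(Cl)cc3s2)c(N[C@@H]2C[C@H](CO)[C@@H](O)[C@H]2O)n1` gives 16000 nM and compound 2 `CN(C)c1ccc2sc(-c3c(Cl)nc(N)nc3N[C@@H]3C[C@H](CO)[C@@H](O)[C@H]3O)nc2c1` gives 25000 nM. Compound 3 `Cc1nc(N)nc(N[C@@H]2C[C@H](CO)[C@@H](O)[C@H]2O)c1-c1nc2ccccc2s1` stands lowest of the three in this assay at 4000 nM, so it is the least tolerated of the set, both gaps being beyond the scatter. Compound 4 `Cc1nc(Nc2nccs2)nc(N[C@@H]2C[C@H](CO)[C@@H](O)[C@H]2O)c1-c1nc2ccccc2s1` differs from compound 3 in one place: 1,3-thiazol-2-yl in place of hydrogen on a nitrogen on an aromatic ring. Going by the values given here, no measured pair shows this change, so nothing here tells its direction. Compound 4 is therefore expected to sit close to compound 3, with the step of no change at the digits printed from compound 3 to compound 4 (within the scatter) estimated as none beyond the scatter. Compound 4 is expected to give 4000 nM, within 1000 nM to 16000 nM.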

Compound 4, half-maximal cytotoxic concentration: 15000 nM
Compound 4: middle estimate off by 3.8-fold (0.57 log units), on the low side, within the range that was stated.
By their numbers in this assay, from the lowest: compound 3; then compounds 4, 1 and 2 (each within the scatter of the next).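

Going by these compounds alone, compound 3 carried a free amino group, and none of the earlier compounds showed any change at that nitrogen. Putting 1,3-thiazol-2-yl in place of hydrogen there gives a 3.8-fold higher number from compound 3 to compound 4 (0.57 log units; beyond the scatter) in this assay, so this position responds to substitution, and the change moves the number up, with more compound tolerated. Nothing measured here explains the rise.

As far as these compounds go, whether this step belongs to the 1,3-thiazol-2-yl ring in particular or to substitution on this nitrogen in general stays open. A methyl group or a phenyl ring on the same nitrogen would separate the two readings.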